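A Methyl Added Twice on Two Related Cores

The compounds below may be only part of what the source reports. "The series", "measured", "known", "first", "only" and "open" are said of these compounds alone.

Compound 1 `Cc1cc(=O)oc2ccc(Oc3ccc(Cl)cc3O)cc12` and compound 2 `CCc1cc(=O)oc2ccc(Oc3ccc(Cl)cc3O)cc12` share one core and differ by a single change, (methyl in place of hydrogen on a saturated chain carbon bound to an aromatic carbon). In an ADME assay on L6 cells (Rattus norvegicus) for inhibition, read by fluorescence, with a stated time of 72 h (a lower number here means a stronger inhibitor, a higher number a weaker inhibitor), compound 1 gives 35500 nM, while compound 2 gives 142000 nM; that is a 4.0-fold higher number from compound 1 to compound 2 (0.60 log units; beyond the scatter). Compound 3 `Cc1cc(=O)oc2cc(Oc3ccc(Cl)cc3O)ccc12` is built from the same atoms as compound 1, joined differently; the difference between the two cores is not broken down here. In this assay compound 3 gives 85900 nM, which sits beyond the scatter from compound 1 but within the scatter of compound 2. Compound 4 `CCc1cc(=O)oc2cc(Oc3ccc(Cl)cc3O)ccc12` has not yet been measured. It differs from compound 3 by methyl in place of hydrogen on a saturated chain carbon bound to an aromatic carbon, the same change already seen from compound 1 to compound 2, made at the same kind of place. Going by the values given here, the expectation rests on compound 3, which gives 85900 nM, and on the earlier step of a 4.0-fold higher number from compound 1 to compound 2 (0.60 log units; beyond the scatter), the only example of this change available. A step of similar size, a 3.5-fold higher number from compound 3 to compound 4 (0.54 log units; beyond the scatter), is expected. Compound 4 is therefore estimated at 300000 nM, plausibly between 120000 nM and 750000 nM.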

Compound 4, half-maximal inhibitory concentration: 84800 nM
Estimate against measurement, compound 4: 3.5-fold (0.55 log units) above, and the stated range ends above it.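

In this assay the same methyl in place of hydrogen gives a 1.0-fold lower number from compound 3 to compound 4 (0.01 log units; within the scatter) and so produces no measurable change on this core, whereas on the core of compound 1 it made the compound a weaker inhibitor. Placed side by side, the two steps differ by more than ordinary repeat variation would explain, so the effect of this change depends on the core in these two pairs: the same change on two cores in this assay, a 4.0-fold higher number (0.60 log units; beyond the scatter) from compound 1 to compound 2 and a 1.0-fold lower number (0.01 log units; within the scatter) from compound 3 to compound 4, 4.1-fold (0.61 log units) apart, beyond the scatter of two such steps

Even so, two pairs are too few to give a rule for the whole series, and these numbers do not reveal what it is about the two cores that separates the steps.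

On these data alone, it remains open whether a longer chain such as propyl, or an amine or a carboxylic acid, placed on the same saturated chain carbon bound to an aromatic carbon, would also behave differently on the two cores. The compounds shown also leave open whether the methyl to ethyl difference would split the two cores in the same way in any other assay.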